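The compounds below may be only part of what the source reports. "The series", "measured", "known", "first", "only" and "open" are said of these compounds alone.

Going by the values given here, compound 1 `COC(=O)c1ccc2ccc(C=O)c-2cc1` is one of two compounds measured so far in an assay on cells for displacement of a labelled ligand from Orexin/Hypocretin receptor type 1 (Homo sapiens), read by scintillation counting, with stated times of 10 min and 90 min, tested at 10 uM; on this read-out higher numbers stand for more inhibition at the one concentration tested (going by the name of the read-out) and lower numbers for less inhibition. In this assay compound 1 gives 25%, which is the lowest of the two numbers. Its nearest neighbour is compound 2 `O=Cc1ccc2ccc(C(=O)O)ccc1-2`, which gives 37.8% in this assay. Among the compounds with values here, the only measured step is the one a number 12.8 percentage points higher from compound 1 to compound 2 (beyond the scatter), where the change is hydrogen in place of methyl on an oxygen next to a carbonyl group.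

Compound 3 `COC(=O)c1ccc2c(C=O)cc(-c3ccccc3)c-2cc1` has not yet been measured. It differs from compound 1 by phenyl in place of hydrogen on an aromatic carbon. Within the data shown here, the single measured step concerns a different place and a different group, so it does not bear on the phenyl for hydrogen exchange, and there is no measured step from which the direction or size of the change in this assay can be read. The estimate therefore rests on compound 1 alone, and the expected step is a number 5 percentage points higher from compound 1 to compound 3 (within the scatter), with no clear direction beyond the scatter. For compound 3 the estimate in this assay is 30%, within a range from 8% to 58%.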

Compound 3, a percentage reported as inhibition, at one concentration (the size of the read-out at that concentration, not a potency): 8.5%
Beside the measured number, compound 3's estimate is 21.5 percentage points above it; the measured number falls inside the stated range.
By their numbers in this assay, from the lowest: compound 3; then compound 1; then compound 2.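

Putting phenyl in place of hydrogen on an aromatic carbon of the five-membered aromatic ring, two ring bonds from the ring atom that bears the formyl group, gives a number 16.5 percentage points lower from compound 1 to compound 3 (beyond the scatter) in this assay, which shows that this place on the core is not indifferent to substitution, at least for this one group. Going by these compounds alone, the only earlier step, a number 12.8 percentage points higher from compound 1 to compound 2 (beyond the scatter), concerned a different place and went the other way, so this is the first measured change that lowers the number and the first information about this ring carbon. No separate measurement bears on why the number falls when the phenyl group enters.

The compounds shown offer only phenyl at this place, so it remains open whether an amine, a hydroxyl group or a longer carbon chain on the same aromatic carbon would lower the number as well, leave it within the scatter, or raise it. On these data alone, it is also open whether adding phenyl to compound 2 would bring a step of similar size and the same direction.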